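The compounds below may be only part of what the source reports. "The series", "measured", "known", "first", "only" and "open" are said of these compounds alone.

Series in a functional assay on HepG2 cells (Homo sapiens) for cytotoxicity; on this read-out lower numbers stand for stronger inhibition and higher numbers for weaker inhibition:
- compound 1 `CO[C@H]1C=C(COC(C)=O)C(=O)[C@H](O)[C@H]1O`: > 50000 nM, a limit of the assay
- compound 2 `CCCCCO[C@H]1C=C(COC(C)=O)C(=O)[C@H](O)[C@H]1O`: 16100 nM

Among the measured compounds shown here, compound 2 holds the only actual number, 16100 nM. The other value is a limit: the limit of > 50000 nM in this assay, at which 1 of the 2 values shown sits.

Compound 3 `CCCCCO[C@@H]1C=C(COC(C)=O)C(=O)[C@H](O)[C@H]1O` is not yet measured. Its relation to compound 2 is as follows: the two compounds have the same atoms and bonds and differ only in configuration as drawn: 1 of 3 stereo elements differ; a stereocentre at a saturated ring carbon is drawn S in compound 2 and R in compound 3. For the measured compounds named here, only one measured step bears on this, and only loosely: an at least 3.1-fold lower number from compound 1 to compound 2 (0.49 log units; beyond the scatter). That step puts butyl in place of hydrogen, so it is a change of group and not of configuration. Its size is also only a bound, since one end is a limit. Going by the values given here, it shows that this assay can register a change, but no measured pair tests a change of configuration. The default expectation in this assay is therefore no step beyond the scatter, with wide uncertainty in either direction. The estimate amounts to an expected 1.2-fold higher number from compound 2 to compound 3 (0.09 log units; within the scatter). For compound 3 the expected value is 20000 nM, with an estimated range of 7000 nM to 50000 nM.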

Compound 3, half-maximal inhibitory concentration: 10100 nM
Compound 3: the middle estimate sits 2.0-fold (0.30 log units) above what was measured; measured number inside the range.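

In this assay, among the compounds shown here, the first change of configuration, from S to R at a saturated ring carbon, gives a 1.6-fold lower number from compound 2 to compound 3 (0.20 log units; within the scatter). This step stays within the scatter, so this pair gives no sign that the read-out separates the two drawn configurations at this stereocentre, and the series has no preferred configuration here; the comparison is clean in that nothing else varies: the fact that compounds 2 and 3 differ only in the configuration as drawn. Compound 1 remains the only compound at a limit: the limit of > 50000 nM in this assay, at which 1 of the 3 values shown sits.

Open is whether this stereocentre stays as silent with a different group on its ether oxygen, such as a longer chain like octyl or a chain ending in an amine or a carboxylic acid, since the single pair shown carries only one chain. As far as these compounds go, the other two stereo elements of the shared core remain untested in this assay, as does any replacement of the acetate ester, for instance by an amide, so nothing here says whether those places respond more strongly than this one.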